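The source may hold more compounds than are shown below. What is called first, only, known or untested is meant among the compounds shown, and "the series" means these compounds.

Measured so far:
compound 1 `COc1ccc(/C=C/C[C@H]2C[C@@H]([C@@H](O)c3ccccc3)CO[C@@H]2c2ccccc2)cc1` gives 8300 nM in a functional assay on HeLa cells (Homo sapiens) for cytotoxicity, read by WST assay, with a stated time of 48 h; on this read-out higher numbers stand for weaker inhibition and lower numbers for stronger inhibition
compound 2 `COc1ccc(/C=C/C[C@H]2C[C@@H]([C@@H](O)c3ccccc3)CO[C@@H]2c2ccc(OC)c(OC)c2)cc1OC` gives 15500 nM in this assay

Compound 1 holds the lowest of the two numbers in this assay; its nearest neighbour is compound 2, whose value lies within the scatter of it, so the two are read as equivalent and no order is claimed between them. For the measured compounds named here, no pair of measured compounds differs in one place only, so nothing yet shows how a change on the double-bonded chain carbon moves the read-out.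

Compound 3 `O[C@@H](c1ccccc1)[C@H]1CO[C@H](c2ccccc2)[C@@H](C/C=C/c2cccnc2)C1` is not yet measured in this assay. Against compound 1 the change is pyridin-3-yl in place of 4-methoxyphenyl on a double-bonded chain carbon bound to a double-bonded chain carbon. Cut one bond further out, 2-(4-methoxyphenyl)ethenyl becomes 2-(pyridin-3-yl)ethenyl, and the shared core is otherwise untouched. Going by the values given here, with no step of this kind on record, the expected step is a 1.2-fold higher number from compound 1 to compound 3 (0.08 log units; within the scatter), not clearly beyond the scatter in either direction. Compound 3 is therefore expected to give 10000 nM in this assay, with a range from 3000 nM to 35000 nM.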

Compound 3, half-maximal inhibitory concentration: > 100000 nM
Compound 3: a limit, no number; the forecaster's own chance of this, stated with the estimate: 15%; at least 10-fold (1.00 log units) between middle value and limit.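

For the compounds shown here, exchanging 4-methoxyphenyl for pyridin-3-yl on a double-bonded chain carbon bound to a double-bonded chain carbon is the first change that can be read in one place, and in this assay it gives an at least 12-fold higher number from compound 1 to compound 3 (1.08 log units; beyond the scatter). This place is therefore not indifferent to the group it carries: with the shared core otherwise untouched, this single exchange moves the read-out beyond the scatter. The step is only a lower bound on the change, as compound 3 gives a limit and not a number: the limit of > 100000 nM in this assay, at which 1 of the 3 values shown sits.

The compounds shown cannot separate the loss of the methoxy group from the entry of the ring nitrogen, and the true size of the step also stays open. A plain phenyl or a 4-hydroxyphenyl at this place would tell whether the methoxy group matters, and a pyridin-4-yl or a 4-methoxypyridin-3-yl would tell whether the ring nitrogen does.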